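The source may hold more compounds than are shown below. What is called first, only, known or untested is meant among the compounds shown, and "the series" means these compounds.

In a functional assay on Shh Light II cells (Mus musculus) for inhibition, read by a luciferase reporter (a lower number here means a stronger inhibitor, a higher number a weaker inhibitor), compound 1 (`O=C(NC1CCC(O)CC1)N1CCC(c2nc(-c3ccc4ccccc4n3)no2)CC1`) gives 2700 nM and compound 2 (`O=C(NCC1CCC1)N1CCC(c2nc(-c3ccc4ccccc4n3)no2)CC1`) gives 410 nM while compound 3 (`O=C(Nc1ccccc1C(F)(F)F)N1CCC(c2nc(-c3ccc4ccccc4n3)no2)CC1`) gives 700 nM and so stands within the scatter of compound 2 and under compound 1. The change to compound 4 (`COc1ccccc1OC(=O)N1CCC(c2nc(-c3ccc4ccccc4n3)no2)CC1`) puts 2-methoxyphenoxy in place of (2-(trifluoromethyl)phenyl)amino on a carbonyl carbon. Among the measured compounds shown here, no measured step makes this swap. The closest guides are changes on the amide-type nitrogen, where a 6.6-fold lower number from compound 1 to compound 2 (0.82 log units; beyond the scatter) and a 3.9-fold lower number from compound 1 to compound 3 (0.59 log units; beyond the scatter) are modest and a 1.7-fold higher number from compound 2 to compound 3 (0.23 log units; within the scatter) stays within the scatter. No step beyond the scatter is therefore expected, in either direction, though the uncertainty is wide. The expected step in this assay is a 1.1-fold higher number from compound 3 to compound 4 (0.06 log units; within the scatter) and lies within the scatter. Compound 4 is estimated at 800 nM with 250 nM to 2500 nM as the expected range.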

Compound 4, half-maximal inhibitory concentration: 250 nM
Beside the measured number, compound 4's estimate is 3.2-fold (0.51 log units) above it; the range from low to high includes it.
By their numbers in this assay, from the lowest: compounds 4, 2 and 3 (each within the scatter of the next, the first and the last beyond it); then compound 1.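

In this assay, the carbonyl carbon does not need an amino group: 2-methoxyphenoxy, which has no hydrogen-bond donor, still gives a 2.8-fold lower number from compound 3 to compound 4 (0.45 log units; beyond the scatter) and an 11-fold lower number from compound 1 to compound 4 (1.03 log units; beyond the scatter), while a 1.6-fold lower number from compound 2 to compound 4 (0.21 log units; within the scatter) stays within the scatter. No measurement shown here bears on the reason for these steps. The compounds shown leave open whether the linking oxygen or the methoxy group matters more, as compound 4 changes both at once. A plain phenoxy group or a (2-methoxyphenyl)amino group on the same carbonyl carbon would separate the two.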